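Thiazolyl to oxazolyl exchange: outlook for compound 4

The compounds below may be only part of what the source reports. "The series", "measured", "known", "first", "only" and "open" are said of these compounds alone.

Three measured compounds share a carboxy- and hydroxy-bearing core and carry a five-membered ring with 2 hetero atoms. In a functional assay on the whole organism for inhibition, with Rattus norvegicus as the target, read by paw edema (a lower number here means that less compound is needed, a higher number that more compound is needed for the effect), compound 1 `O=C(O)c1ccc(-c2cscn2)cc1O` gives 70 mg/kg; compound 3 `O=C(O)c1cc(-c2cscn2)ccc1O` gives 95 mg/kg and compound 2 `O=C(O)c1cc(-c2ncco2)ccc1O` gives 100 mg/kg. Compound 3 and compound 2 differ by 1,3-oxazol-2-yl in place of 1,3-thiazol-4-yl on an aromatic carbon, with the step of a 1.1-fold higher number from compound 3 to compound 2 (0.02 log units; within the scatter). Compound 1 and compound 3 have the same atoms joined differently; the difference between the two cores is not broken down here. Compound 4 `O=C(O)c1ccc(-c2ncco2)cc1O` is not yet measured and differs from compound 1 by 1,3-oxazol-2-yl in place of 1,3-thiazol-4-yl on an aromatic carbon. The place differs: meta to a carboxy group and para to a hydroxy group in the measured pair, meta to a hydroxy group and para to a carboxy group here, so this is the same kind of change, not the same. Because the measured step of a 1.1-fold higher number from compound 3 to compound 2 (0.02 log units; within the scatter) lay within the scatter, a similarly small step is expected, a 1.1-fold higher number from compound 1 to compound 4 (0.03 log units; within the scatter). Compound 4 is thus estimated at 75 mg/kg, with a plausible range from 40 mg/kg to 140 mg/kg.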

Compound 4, dose for half-maximal effect: > 250 mg/kg
Compound 4: only a limit was reported; the forecaster's own chance of this, stated with the estimate: 5%; middle value at least 3.3-fold (0.52 log units) away from the limit.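

With the ring para to a carboxy group, 1,3-oxazol-2-yl in place of 1,3-thiazol-4-yl gives an at least 3.5-fold higher number from compound 1 to compound 4 (0.55 log units; beyond the scatter) in this assay, so the change does not carry over unaltered between these two cores: the same change on two cores in this assay, a 1.1-fold higher number (0.02 log units; within the scatter) from compound 3 to compound 2 and an at least 3.5-fold higher number (0.55 log units; beyond the scatter) from compound 1 to compound 4, at least 3.3-fold (0.53 log units) apart, beyond the scatter of two such steps

Compound 4 gives > 250 mg/kg, which is a limit of the assay and not a number: the limit of > 250 mg/kg in this assay, at which 1 of the 4 values shown sits.

With one pair on each core, this shows a dependence on the core for these compounds only; it gives neither a cause nor a rule for other cores.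

Still open, on these data alone, is how 1,3-thiazol-2-yl or 1,3-oxazol-4-yl would read on either core, which would separate the ring hetero atom from the point of attachment. Also open, as far as these compounds go, is the effect of a methyl ester or an amide in place of the carboxy group.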